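Thiourea series: heteroaryl swap on the amine nitrogen

The source may hold more compounds than are shown below. What is called first, only, known or untested is meant among the compounds shown, and "the series" means these compounds.

Measured so far:
compound 1 `Cc1csc(N/C(S)=N/[C@@H](C)c2cccc3ccccc23)n1`, 83200 nM
compound 2 `C[C@@H](/N=C(\S)Nc1ccc(Cl)cn1)c1cccc2ccccc12`, > 100000 nM; > 100000 nM (2 entries)
compound 3 `Cc1cc(C)nc(N/C(S)=N/[C@@H](C)c2cccc3ccccc23)c1`, > 100000 nM

In a functional assay on RBL-2H3 cells (Rattus norvegicus) for inhibition (a higher number here means a weaker inhibitor, a lower number a stronger inhibitor), compound 1 gives 83200 nM. For compound 2 the value > 100000 nM; > 100000 nM (2 entries) is a limit of this assay, not a number. For compound 3 the value > 100000 nM is likewise a limit of this assay; no single number stands for it, and it sits at the limit of > 100000 nM in this assay, at which 1 of the 3 values shown sits.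

Compound 4 `C[C@H](/N=C(\S)Nc1nccs1)c1cccc2ccccc12` is not yet measured. Relative to compound 3 the change is 1,3-thiazol-2-yl in place of 4,6-dimethylpyridin-2-yl on an amine nitrogen. Within the data shown here, the one measured step that touches this position is an at least 1.2-fold higher number from compound 1 to compound 3 (0.07 log units; that floor lies within the scatter), and it starts from a limit, so only its floor is known. Compound 4 carries the same five-membered ring type as compound 1 but without the methyl, so its number is expected near that of compound 1 rather than further out than compound 3. The step is estimated as an at least 1.1-fold lower number from compound 3 to compound 4 (0.04 log units; that floor lies within the scatter), pointing toward a smaller number, though a limit remains possible. Compound 4 is expected at 90000 nM, within 40000 nM to 250000 nM.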

Compound 4, half-maximal inhibitory concentration: > 100000 nM
Compound 4: only a limit was reported; the forecaster's own chance of this, stated with the estimate: 45%; middle value at least 1.1-fold (0.04 log units) away from the limit.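

Hydrogen in place of methyl on an aromatic carbon gives an at least 1.2-fold higher number from compound 1 to compound 4 (0.07 log units; that floor lies within the scatter) and so leaves the contribution of that methyl unsized. The two limits leave the step from compound 3 to compound 4 unreadable. Compound 4 is reported in this assay only as a limit, which shows that this position reaches the limit with a five-membered aromatic ring as well as with the six-membered ring of compound 3: the limit of > 100000 nM in this assay, at which 2 of the 4 values shown sit.

Compound 1 gives 83200 nM and is the only compound shown here with a single number, so the range of this position in this assay remains undefined. Open, from the compounds shown here alone, is whether an amine or a carboxylic acid on the 1,3-thiazol-2-yl ring, or a longer chain in place of its hydrogen, would give a number clearly clear of the limit.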